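The source may report more compounds than this note shows. Statements on the series, on what has been measured and on what is new or still open speak of the compounds shown alone.

Three compounds from this series were measured in a functional assay on the whole organism for inhibition, with Nicotiana tabacum as the target; a lower number here means a stronger inhibitor, a higher number a weaker inhibitor. Compound 1 `Cc1nc(Nc2ccc(I)cc2)c2cc[nH]c2n1` gives 219000000 nM, compound 3 `Cc1nc(Nc2ccc(O)cc2)c2cc[nH]c2n1` gives 155000000 nM, and compound 2 `Cc1ccc(Nc2[nH]c(C)nc3nccc2-3)cc1` gives 759000000 nM, the highest of the three numbers; its nearest neighbour is compound 1 and its furthest is compound 3, and both gaps lie beyond the scatter. The step between compound 1 and compound 3 a 1.4-fold lower number from compound 1 to compound 3 (0.15 log units; within the scatter) exchanges one substituent at the aryl ring and barely moves the number.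

Compound 4 `COc1ccc(Nc2[nH]c(C)nc3nccc2-3)cc1` differs from compound 2 by methoxy in place of methyl on an aromatic carbon. Among the measured compounds shown here, only the step from compound 1 to compound 3 bears on a change at this position, and it was within the scatter, so no evidence here points to a move beyond the scatter in this assay for compound 4. The estimate for compound 4 in this assay is therefore 550000000 nM, with a range from 200000000 nM to 1500000000 nM, which is expected to amount to a step of a 1.4-fold lower number from compound 2 to compound 4 (0.14 log units; within the scatter).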

Compound 4, half-maximal inhibitory concentration: 661000000 nM
Compound 4: the middle estimate sits 1.2-fold (0.08 log units) below what was measured, within the range that was stated.
By their numbers in this assay, from the lowest: compounds 3 and 1 (each within the scatter of the next); then compounds 4 and 2 (each within the scatter of the next).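

In this assay, the step of a 1.1-fold lower number from compound 2 to compound 4 (0.06 log units; within the scatter) shows that methoxy can replace methyl on this aromatic carbon, para to a large group, without a move beyond the scatter, even though it adds one heavy atom and a hydrogen-bond acceptor. The earlier step within the scatter belonged to the core of compound 1, so this result extends the same reading to the core of compound 2: neither listed change at this position moves the number beyond the scatter. No available evidence bears on this result. The compounds shown leave open whether an amine, a carboxylic acid or a longer chain at this position would move the number beyond the scatter. They also leave open whether any such group would have the same effect on both cores.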